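Indole for Imidazole on Two Related Cores

A few compounds are considered here, and "the series" means these few. Any claim that something is new, unique, unknown or untested is made for them only; others in the source may bear on it.

Compound 1 `Cc1cc(-n2ccnc2)cn2c(CSCCc3ccccc3)cnc12` and compound 2 `Cc1cc(-n2ccc3ccccc32)cn2c(CSCCc3ccccc3)cnc12` share one core, while compound 3 `Cc1cc(-n2ccnc2)c2ncc(CSCCc3ccccc3)n2c1` and compound 4 `Cc1cc(-n2ccc3ccccc32)c2ncc(CSCCc3ccccc3)n2c1` share another; the difference between the two cores is not broken down here. In an ADME assay on HEL cells (Homo sapiens) for cytotoxicity, with a stated time of 3 days (a lower number here means that less compound is tolerated, a higher number that more compound is tolerated), compound 1 gives 23 ug/mL and compound 2 gives 18 ug/mL. The change between them is 1H-indol-1-yl in place of 1H-imidazol-1-yl on an aromatic carbon, and it made a 1.3-fold lower number from compound 1 to compound 2 (0.11 log units; within the scatter). In this assay compound 3 gives 10 ug/mL. Compound 4 carries the same kind of change relative to compound 3, namely (1H-indol-1-yl in place of 1H-imidazol-1-yl on an aromatic carbon), though its place is ortho to a fused ring where in compound 2 it was para to a fused ring. Because a 1.3-fold lower number from compound 1 to compound 2 (0.11 log units; within the scatter), the expected outcome is a 1.3-fold lower number from compound 3 to compound 4 (0.10 log units; within the scatter). Compound 4 is therefore estimated at 8 ug/mL in this assay, most likely between 4 ug/mL and 16 ug/mL.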

Compound 4, half-maximal cytotoxic concentration: > 100 ug/mL
Compound 4 gave a limit, no number; the forecaster's own chance of this, stated with the estimate: 5%; middle value at least 12-fold (1.09 log units) from the limit.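

The change of 1H-imidazol-1-yl to 1H-indol-1-yl on an aromatic carbon gave an at least 10-fold higher number from compound 3 to compound 4 (1.00 log units; beyond the scatter), so the outcome on the core of compound 1 did not carry over to the core of compound 3: the same change on two cores in this assay, a 1.3-fold lower number (0.11 log units; within the scatter) from compound 1 to compound 2 and an at least 10-fold higher number (1.00 log units; beyond the scatter) from compound 3 to compound 4, at least 12-fold (1.10 log units) apart, beyond the scatter of two such steps. In this assay compound 4 gives > 100 ug/mL, which is a limit of the assay and not a number: the limit of > 100 ug/mL in this assay, at which 1 of the 4 values shown sits. With one pair on each core, this shows that the same change can end differently on these two cores, but it shows neither the full size of the new step nor what lies behind the gap.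

The compounds shown leave open whether a similar gap between the two cores would appear with other groups on that aromatic carbon, such as an amine or a carboxylic acid.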